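A few compounds are considered here, and "the series" means these few. Any claim that something is new, unique, unknown or untested is made for them only; others in the source may bear on it.

Measured compounds in a functional assay on HT-29 cells (Homo sapiens) for cytotoxicity, read by MTT assay, with a stated time of 72 h; a higher number here means a weaker inhibitor, a lower number a stronger inhibitor:
Compound 1 `COc1cc2c(Oc3ccc(NC(=O)c4cn(-c5ccccc5)nn4)cc3F)ccnc2cc1OCCCN1CCCC1` gives 180 nM.
Compound 2 `COc1cc2c(Oc3ccc(NC(=O)c4cn(-c5ccccc5)nn4)cc3F)ccnc2cc1OCCCN1CCCCC1` gives 180 nM.
Compound 3 `COc1cc2c(Oc3ccc(NC(=O)c4cn(-c5ccc(Br)cc5)nn4)cc3F)ccnc2cc1OCCCN1CCCCC1` gives 260 nM.

Compound 2 stands level with compound 1 at the digits shown, and together these two carry the lowest numbers of the three. The step to compound 3 is a 1.4-fold higher number from compound 2 to compound 3 (0.16 log units; within the scatter), so all three compounds sit within the scatter of one another. Compound 4 `COc1cc2c(Oc3ccc(NC(=O)c4cn(-c5ccccc5)nn4)cc3F)ccnc2cc1OCCCN1CCC(C)CC1` has not yet been measured. Its change from compound 2 is methyl in place of hydrogen on a saturated ring carbon. Among the compounds with values here, two measured steps bear on this. The step of no change at the digits printed from compound 1 to compound 2 (within the scatter) touches the same saturated ring, swapping pyrrolidin-1-yl for piperidin-1-yl without effect. The step of a 1.4-fold higher number from compound 2 to compound 3 (0.16 log units; within the scatter) adds a bromo elsewhere, again within the scatter. A small methyl on the same ring is therefore expected to leave the number essentially where it is, with no step beyond the scatter in either direction. Compound 4 is expected to give about 180 nM in this assay, with a range from 90 nM to 360 nM. This estimate amounts to no change at the digits printed from compound 2 to compound 4 (within the scatter), expected to stay within the scatter.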

Compound 4, half-maximal inhibitory concentration: 190 nM
Beside the measured number, compound 4's estimate is 1.1-fold (0.02 log units) below it; low and high end bracket the measured number.
By their numbers in this assay, from the lowest: compounds 1, 2, 4 and 3 (each within the scatter of the next).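

In this assay, methyl on the saturated ring carbon, three ring bonds from the ring nitrogen, gives a 1.1-fold higher number from compound 2 to compound 4 (0.02 log units; within the scatter). This is the first substituent shown on this ring, whereas the earlier ring change only swapped pyrrolidin-1-yl for piperidin-1-yl, and the result shows that this ring carbon accepts a methyl without a step beyond the scatter. Replacing pyrrolidin-1-yl with 4-methylpiperidin-1-yl gives a 1.1-fold higher number from compound 1 to compound 4 (0.02 log units; within the scatter), so the three ring amines shown here cannot be told apart in this assay, and no measurement is available that would explain this.

As far as these compounds go, whether a hydroxyl, a carboxylic acid or a phenyl at this ring carbon would also stay within the scatter remains open. So does the outcome of swapping the ring for piperazine or morpholine, or of using a longer chain to the ring nitrogen.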